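The source may report more compounds than this note shows. Statements on the series, on what has been measured and on what is new or still open speak of the compounds shown alone.

Among the compounds with values here, in a functional assay on A549 cells (Homo sapiens) for inhibition, read by MTT assay, with a stated time of 48 h (a higher number here means a weaker inhibitor, a lower number a stronger inhibitor), compound 3 (`COc1ccc(C(c2c[nH]c3ccc(Br)cc23)c2c[nH]c3ccc(Br)cc23)cc1OC`) gives 12000 nM and is the strongest inhibitor of the three measured so far. Compound 1 (`COc1cccc(C(c2c[nH]c3ccc(Br)cc23)c2c[nH]c3ccc(Br)cc23)c1OC`) gives 100000 nM and compound 2 (`COc1ccc(C(c2c[nH]c3ccc(Br)cc23)c2c[nH]c3ccc(Br)cc23)c(OC)c1`) gives 100000 nM in the same test.

Compound 4 (`Brc1ccc2[nH]cc(C(c3c[nH]c4ccc(Br)cc34)C3CCCCC3)c2c1`) is still unmeasured. It carries cyclohexyl in place of 3,4-dimethoxyphenyl on a saturated chain carbon bound to two aromatic carbons and so keeps a six-membered ring but loses its aromatic character and both oxygens.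

Three measured steps offer some guidance, though all of them only swap one dimethoxyphenyl for another. The step of no change at the digits printed from compound 1 to compound 2 (within the scatter) shows nothing beyond the scatter. The steps of an 8.3-fold lower number from compound 1 to compound 3 (0.92 log units; beyond the scatter) and an 8.3-fold lower number from compound 2 to compound 3 (0.92 log units; beyond the scatter) are modest but real, and both favour the 3,4-dimethoxyphenyl group. Within the data shown here, no measured compound lacks an aromatic ring here, so this is only a loose guide.

Leaving that group is therefore expected to cost some activity, with an expected step of a 2.9-fold higher number from compound 3 to compound 4 (0.46 log units; beyond the scatter) toward a weaker inhibitor, no larger than those two. For compound 4 the estimate is 35000 nM with 9000 nM to 100000 nM as the expected range.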

Compound 4, half-maximal inhibitory concentration: 5500 nM
Estimate against measurement, compound 4: 6.4-fold (0.80 log units) above; the measured number lies below the stated range.
By their numbers in this assay, from the lowest: compound 4; then compound 3; then compounds 1 and 2 (each within the scatter of the next).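

In this assay this position turns out to need neither an aromatic ring nor any oxygen: cyclohexyl gives a 2.2-fold lower number from compound 3 to compound 4 (0.34 log units; beyond the scatter) and so outperforms even the best dimethoxyphenyl group shown. Against the two weaker dimethoxyphenyl groups the change is larger, with an 18-fold lower number from compound 2 to compound 4 (1.26 log units; beyond the scatter) and an 18-fold lower number from compound 1 to compound 4 (1.26 log units; beyond the scatter) as its size, which makes compound 4 the strongest inhibitor of the four. No measurement shown offers an explanation for this gain.

Within the data shown here, only one non-aromatic ring appears here, so it remains open whether cyclopentyl, an open butyl chain or a cyclohexyl ring carrying an amine would do as well. Also open, as far as these compounds go, is how plain unsubstituted phenyl would compare, which would help separate the loss of the two methoxy groups from the loss of the aromatic ring.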